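The compounds below may be only part of what the source reports. "The series", "measured", "known", "first", "only" and "open" are said of these compounds alone.

Compound 1, with the structure `CNC(=O)/C=C/c1ccncc1-c1ccc2ccccc2c1`, is the starting point. In a functional assay on KB cells (Homo sapiens) for inhibition, read by sulforhodamine B assay, with a stated time of 72 h (a lower number here means a stronger inhibitor of growth, a higher number a weaker inhibitor of growth), compound 1 gives only a limit of the assay, > 10000 nM, and not a number. Compound 2, with the structure `O=C(/C=C/c1ccncc1-c1ccc2ccccc2c1)N1CCOCC1`, carries morpholin-4-yl in place of methylamino on a carbonyl carbon; in this assay compound 2 also gives only a limit, > 10000 nM. Compound 3, with the structure `O=C(O)/C=C/c1ccncc1-c1ccc2cc[nH]c2c1`, likewise gives only a limit in this assay, > 10000 nM. Among the compounds with values here, the one step between measured compounds, a step that the two limits leave unreadable from compound 1 to compound 2, is therefore of unknown size, and all that can be said is summed up by the observation that (the limit of > 10000 nM in this assay, at which 3 of the 3 values shown sit).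

Compound 4, with the structure `O=C(O)CCc1ccncc1-c1ccc2ccccc2c1`, is not yet measured. Relative to compound 1 the change is 2-carboxyethyl in place of 2-(methylcarbamoyl)ethenyl on an aromatic carbon. Within the data shown here, no measured step speaks to this change, so no direction or size can be read for it; the expectation is only that compound 4 stays where the three measured compounds sit. Compound 4 is estimated at 20000 nM in this assay, within a range from 5000 nM to 80000 nM, which is expected to mean a step that the limit leaves unreadable from compound 1 to compound 4.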

Compound 4, concentration for 50% growth inhibition: > 10000 nM
Compound 4: no number, only a limit; the forecaster's own chance of this, stated with the estimate: 85%; the middle value does not contradict the limit.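

In this assay compound 4 gives > 10000 nM, a limit and not a number. Within the data shown here, compound 1 also gives only a limit, so no step from compound 1 to compound 4 can be read. Which change to the shared core, if any, would give a readable number stays open, with all the compounds at one point: the limit of > 10000 nM in this assay, at which 4 of the 4 values shown sit.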